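The compounds below may be only part of what the source reports. "The series", "measured", "known", "first", "only" and "open" are said of these compounds alone.

Compound 1 `CN1Cc2cc(ccc2S(=O)(=O)C2CC2)NC(=O)CCc2cc(ccc2OCC2CC2)[C@@H](Nc2ccc3c(N)ncc(F)c3c2)C1=O`: 0.383 h
Compound 2 `CN1CCc2cccc(c2)[C@@H](Nc2ccc3c(N)ncc(F)c3c2)C(=O)N(C)Cc2cc(ccc2S(=O)(=O)C2CC2)NC1=O`: 0.1 h
Compound 3 `COc1ccc2cc1[C@@H](C)CN(C)C(=O)Nc1ccc(S(=O)(=O)C3CC3)c(c1)CN(C)C(=O)[C@@H]2Nc1ccc2c(N)ncc(F)c2c1`: 0.0667 h

These three compounds were tested in an ADME assay on liver (Rattus norvegicus) for metabolic stability, using microsomes; a lower number here means that the compound disappears faster, a higher number that the compound lasts longer. Compound 1 gives the highest of the three numbers, 0.383 h, and compound 2 and compound 3 both lie lower by more than the usual scatter.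

Compound 4 `CN1Cc2cc(ccc2S(=O)(=O)C2CC2)NC(=O)CCc2cccc(c2)[C@@H](Nc2ccc3c(N)ncc(F)c3c2)C1=O` has not yet been measured. It carries hydrogen in place of cyclopropylmethoxy on an aromatic carbon. Within the data shown here, no two measured compounds differ in one place only, so the data do not show this change on its own. In this assay, on these data alone, no step beyond the scatter is therefore expected, though either direction remains open. The estimated change is a 1.3-fold lower number from compound 1 to compound 4 (0.11 log units; within the scatter). For compound 4 the expected value is 0.3 h, with an estimated range from 0.12 h to 0.75 h.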

Compound 4, half-life: 0.55 h
Compound 4: the middle estimate sits 1.8-fold (0.26 log units) below what was measured, within the range that was stated.
By their numbers in this assay, from the lowest: compounds 3 and 2 (each within the scatter of the next); then compounds 1 and 4 (each within the scatter of the next).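

Among these compounds, this is the first comparison in the set that changes only one place: in this assay, hydrogen in place of cyclopropylmethoxy gives a 1.4-fold higher number from compound 1 to compound 4 (0.16 log units; within the scatter), which lies within the usual scatter. On this aromatic carbon, the whole cyclopropylmethoxy group, ring and oxygen included, can therefore go without a measurable step in half-life. No measured evidence here explains this result. On these data alone, what a carboxylic acid or an amine on this same aromatic carbon would do to the half-life remains open. So does whether this replacement gives a similar step on another core.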